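The source may report more compounds than this note shows. Statements on the series, on what has been measured and on what is new or still open speak of the compounds shown alone.

Working notes on the series. Compound 1 `COc1ccc(-c2cc(/C=C/C(=O)c3ccc(N)cc3)[nH]n2)cc1` and compound 3 `COc1ccc(-c2cc(/C=C/C(=O)c3ccc(N)cc3)[nH]n2)cc1OC` share one core; compound 2 `COc1ccc(C(=O)/C=C/c2cc(-c3cc(OC)c(OC)c(OC)c3)n[nH]2)cc1OC` and compound 4 `COc1cc(C(=O)/C=C/c2cc(-c3cc(OC)c(OC)c(OC)c3)n[nH]2)cc(OC)c1OC` share another, and the difference between the two cores is not broken down here. In a functional assay on MOLT-4 cells (Homo sapiens) for inhibition, read by sulforhodamine B assay, with a stated time of 48 h (a higher number here means that more compound is tolerated, a lower number that less compound is tolerated), compound 1 gives only a limit, > 100000 nM. In this assay compound 3 likewise gives only a limit, > 100000 nM. In this assay compound 2 also gives only a limit, > 100000 nM. The change from compound 1 to compound 3 is methoxy in place of hydrogen on an aromatic carbon, and its size is a step that the two limits leave unreadable from compound 1 to compound 3, because of the limit of > 100000 nM in this assay, at which 3 of the 3 values shown sit.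

Compound 4 is not yet measured in this assay. It carries the same kind of change, (methoxy in place of hydrogen on an aromatic carbon); around the place the two differ in that here the new group is also meta to a methoxy group. Within the data shown here, since compound 2 sits at a limit, > 100000 nM, and the only measured step of this kind is unreadable, the expectation for the step from compound 2 to compound 4 is a number no higher from compound 2 to compound 4 (the limit leaves the size open). For compound 4 in this assay the estimate is 100000 nM, between 30000 nM and 300000 nM, most likely reported again as a limit.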

Compound 4, concentration lethal to 50% of the cells: > 100000 nM
Compound 4 was reported as a limit; the forecaster's own chance of this, stated with the estimate: 80%; the middle value lies on the limit itself.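

The step from compound 2 to compound 4, methoxy in place of hydrogen on an aromatic carbon, cannot be read, and no new step comes out of this result, because both compounds stand at a limit: the limit of > 100000 nM in this assay, at which 4 of the 4 values shown sit.

The compounds shown leave open whether methoxy in place of hydrogen on an aromatic carbon changes the read-out on either core in this assay, and how the two cores compare.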